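Cyclopentyl in Place of 2-Methylbutyl on the Ether Oxygen

The compounds below may be only part of what the source reports. "The series", "measured", "known", "first", "only" and "open" are said of these compounds alone.

Measured compounds:
compound 1 `CCC(C)COc1cccc2ccc(N)nc12` — 36 nM
compound 2 `CC(CC(C)(C)C)Oc1cccc2ccc(N3CCCCC3)nc12` — > 2000 nM
compound 3 `CC(CC(C)(C)C)Oc1cccc2ccc(N(C)C)nc12` — > 2000 nM

For the measured compounds named here, in an assay on cells with melanin-concentrating hormone receptor 1 (Homo sapiens) as the target, read by radioligand binding (on this read-out higher numbers stand for weaker inhibition and lower numbers for stronger inhibition), compound 1 gives 36 nM, the only true number among the three values shown. For compound 2 the assay reports only a limit, > 2000 nM. For compound 3 it likewise reports only a limit, > 2000 nM. The step that the two limits leave unreadable from compound 2 to compound 3 therefore cannot be read, since both compounds sit at the limit of > 2000 nM in this assay, at which 2 of the 3 values shown sit.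

Compound 4 `Nc1ccc2cccc(OC3CCCC3)c2n1` differs from compound 1 by cyclopentyl in place of 2-methylbutyl on an oxygen on an aromatic ring. Going by the values given here, no measured step changes the group on that oxygen alone: compounds 2 and 3 carry both a different chain on the oxygen and a different amine, so they give no reading of this change. The group that leaves and the group that enters are alike in count of heavy atoms, and the author therefore expects the step of a 1.1-fold higher number from compound 1 to compound 4 (0.05 log units; within the scatter) to stay within the usual scatter. On that basis compound 4 is estimated at 40 nM, with a range from 12 nM to 130 nM.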

Compound 4, half-maximal inhibitory concentration: > 2000 nM
Compound 4 was reported as a limit; the forecaster's own chance of this, stated with the estimate: 5%; middle value at least 50-fold (1.69 log units) from the limit.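

In this assay, for the compounds shown here, changing only the group on the oxygen gives an at least 55-fold higher number from compound 1 to compound 4 (1.74 log units; beyond the scatter), the first reading of this position with the rest of the molecule held fixed. The result shows that a matching count of heavy atoms does not make two groups interchangeable here, since 2-methylbutyl has no ring and cyclopentyl is a five-membered non-aromatic ring of carbon only. Compound 4 stands at a limit of the assay, not at a true number: the limit of > 2000 nM in this assay, at which 3 of the 4 values shown sit.

Going by these compounds, it remains open whether an open chain such as n-pentyl or 3-methylbutyl, or a ring such as cyclobutyl or cyclohexyl, would stay near compound 1, which gives 36 nM. Also open, on these data alone, is how piperidin-1-yl or dimethylamino in place of the free amine would read with 2-methylbutyl on the oxygen.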